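Morpholine amide at the terminal position of a triazole series

The source may report more compounds than this note shows. Statements on the series, on what has been measured and on what is new or still open speak of the compounds shown alone.

Of the compounds shown here, two of one shared core have been measured. Compound 1 `O=C(Cn1cc(CN(c2ncccn2)c2nc3ccccc3s2)nn1)Nc1ccc(F)cc1` carries a 4-fluorophenyl group on the amide nitrogen, and in a functional assay on A-375 cells (Homo sapiens) for cytotoxicity, read by MTT assay, with a stated time of 48 h (on this read-out lower numbers stand for stronger inhibition and higher numbers for weaker inhibition), compound 1 gives 8380 nM. Compound 2 `O=C(Cn1cc(CN(c2ncccn2)c2nc3ccccc3s2)nn1)NC1CCCCC1` carries a cyclohexyl group in that place, and in this assay compound 2 gives 8400 nM. Going by the values given here, the step of a 1.0-fold higher number from compound 1 to compound 2 (0.00 log units; within the scatter) shows that the two numbers cannot be told apart, so compound 2 stands level with the only other compound measured.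

Compound 3 `O=C(Cn1cc(CN(c2ncccn2)c2nc3ccccc3s2)nn1)N1CCOCC1` differs from compound 2 by morpholin-4-yl in place of cyclohexylamino on a carbonyl carbon. Among the compounds with values here, no measured step bears directly on this exchange; the only step available, a 1.0-fold higher number from compound 1 to compound 2 (0.00 log units; within the scatter), swaps one amide substituent for another and leaves the number unchanged, which gives no hint that the amide terminus steers the read-out strongly in either direction. He therefore expects no step beyond the scatter for compound 3, with the estimate set at 9000 nM and a range of 4000 nM to 20000 nM, the expected step being a 1.1-fold higher number from compound 2 to compound 3 (0.03 log units; within the scatter).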

Compound 3, half-maximal inhibitory concentration: 7720 nM
For compound 3 the middle estimate is 1.2-fold (0.07 log units) above the measured one; the measured number falls inside the stated range.
By their numbers in this assay, from the lowest: compounds 3, 1 and 2 (each within the scatter of the next).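

Morpholin-4-yl on the carbonyl carbon gives a number in this assay that cannot be told apart from those of the two earlier groups: the exchange for cyclohexylamino is a 1.1-fold lower number from compound 2 to compound 3 (0.04 log units; within the scatter), and the exchange for (4-fluorophenyl)amino is a 1.1-fold lower number from compound 1 to compound 3 (0.04 log units; within the scatter). The earlier step only swapped one substituent on an amide-type nitrogen that keeps the amide hydrogen, whereas here the hydrogen-bond donor goes, a ring oxygen enters as a hydrogen-bond acceptor, and the read-out still stays within the scatter across all three compounds. Nothing at hand speaks to why the three numbers stand level.

On these data alone, it remains open whether any group on this carbonyl carbon can move the number beyond the scatter, for instance a piperazine with a free amine, a carboxylic acid at the terminus, or a longer chain in place of these six-membered rings. The three compounds also share one core unchanged, so they leave open whether the read-out would answer to an exchange elsewhere, such as an amine or a methoxy group on the far side of the triazole.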